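Furanopyrimidinone series: cyclopropyl to 3-chloropropyl at the furan carbon

A few compounds are considered here, and "the series" means these few. Any claim that something is new, unique, unknown or untested is made for them only; others in the source may bear on it.

Measured so far in a functional assay on HeLa cells (Homo sapiens) for antiproliferative activity, read by MTT assay, with a stated time of 72 h; a higher number here means a weaker inhibitor, a lower number a stronger inhibitor:
compound 1, `CCCCCCC#Cc1c(CCCCCC)oc2nc(=O)n(Cc3cn(Cc4ccccc4)nn3)cc12`, 23400 nM
compound 2, `O=c1nc2oc(C3CC3)cc2cn1Cc1cn(-c2ccc(Cl)cc2)nn1`, reported only as a limit, > 100000 nM

Compound 2 sits at the limit of > 100000 nM in this assay, at which 1 of the 2 values shown sits, so no number stands for it. Compound 3, `O=c1nc2oc(CCCCl)cc2cn1Cc1cn(-c2ccc(Cl)cc2)nn1`, carries 3-chloropropyl in place of cyclopropyl on an aromatic carbon. Within the data shown here, no measured step of this kind exists, and compound 1 shows that a longer chain at that position still gives only weak inhibition. Compound 3 is therefore expected to remain weak, the estimated step being an at least 1.2-fold lower number from compound 2 to compound 3 (0.09 log units; that floor lies within the scatter). The expected value for compound 3 is 80000 nM, within 30000 nM to 200000 nM.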

Compound 3, half-maximal inhibitory concentration: 60200 nM
The estimate for compound 3 lay 1.3-fold (0.12 log units) above the measured number; the measured number falls inside the stated range.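

In this assay, 3-chloropropyl in place of cyclopropyl on this aromatic carbon gives an at least 1.6-fold lower number from compound 2 to compound 3 (0.22 log units; that floor lies within the scatter). Compound 2 is reported only as a limit, so the true size of the step cannot be read: the limit of > 100000 nM in this assay, at which 1 of the 3 values shown sits.

Compound 3, at 60200 nM, gives this position a measured number with an open chain, and that number remains weak.

From the compounds shown here alone, it remains open whether the chlorine or the chain itself matters here. A plain propyl chain or an aminopropyl chain in the same place would separate the two.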